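Trifluoromethyl for Bromo on a Benzimidazole Sulfonamide Series

This account rests on a few compounds, and the source may have more. Where it says the series, first, only, none or still open, it means among the compounds named here.

The study covers three measured compounds and one not yet measured. Compound 1 `O=S(=O)(c1ccc(Br)cc1)n1c(-c2cn(-c3ccccc3)nc2-c2ccc(F)cc2)nc2ccccc21` gives 1720 nM in a functional assay on A549 cells (Homo sapiens) for antiproliferative activity, read by MTT assay, with a stated time of 24 h; a higher number here means a weaker inhibitor, a lower number a stronger inhibitor. Compound 2 `O=S(=O)(c1ccc(C(F)(F)F)cc1)n1c(-c2cn(-c3ccccc3)nc2-c2ccc(F)cc2)nc2ccccc21` differs from compound 1 by trifluoromethyl in place of bromo on an aromatic carbon. In this assay compound 2 gives 1280 nM, a step of a 1.3-fold lower number from compound 1 to compound 2 (0.13 log units; within the scatter). Compound 3 `O=S(=O)(c1ccc(Br)cc1)n1c(-c2cn(-c3ccccc3)nc2-c2ccc(C(F)(F)F)cc2)nc2ccccc21` differs from compound 1 in its core by trifluoromethyl in place of fluoro on an aromatic carbon. In this assay compound 3 gives 1690 nM, a step of a 1.0-fold lower number from compound 1 to compound 3 (0.01 log units; within the scatter). Compound 3 and compound 2 are not joined by a single change, and their two values lie close to one another.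

Compound 4 `O=S(=O)(c1ccc(C(F)(F)F)cc1)n1c(-c2cn(-c3ccccc3)nc2-c2ccc(C(F)(F)F)cc2)nc2ccccc21` carries the same change relative to compound 3 that compound 2 carries relative to compound 1: trifluoromethyl in place of bromo on an aromatic carbon. The place of the change is described in identical words for both pairs, so it is the same change on a different core. The expected step of a 1.3-fold lower number from compound 3 to compound 4 (0.11 log units; within the scatter) rests on the measured step of a 1.3-fold lower number from compound 1 to compound 2 (0.13 log units; within the scatter), which stayed within the scatter, and on the near-equal values of compound 1 and compound 3. Compound 4 is therefore estimated at 1300 nM, with a range from 700 nM to 2500 nM.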

Compound 4, half-maximal inhibitory concentration: 860 nM
Beside the measured number, compound 4's estimate is 1.5-fold (0.18 log units) above it; low and high end bracket the measured number.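

In this assay, for the compounds shown here, trifluoromethyl in place of bromo gives a 2.0-fold lower number from compound 3 to compound 4 (0.29 log units; within the scatter), and this does not differ beyond the scatter from the same change on the core of compound 1: the same change on two cores in this assay, a 1.3-fold lower number (0.13 log units; within the scatter) from compound 1 to compound 2 and a 2.0-fold lower number (0.29 log units; within the scatter) from compound 3 to compound 4, 1.5-fold (0.17 log units) apart, within the scatter of two such steps Trifluoromethyl in place of fluoro gives a 1.5-fold lower number from compound 2 to compound 4 (0.17 log units; within the scatter), and this change also carries from one core to the other without a difference beyond the scatter: the same change on two cores in this assay, a 1.0-fold lower number (0.01 log units; within the scatter) from compound 1 to compound 3 and a 1.5-fold lower number (0.17 log units; within the scatter) from compound 2 to compound 4, 1.5-fold (0.17 log units) apart, within the scatter of two such steps Both changes therefore behave alike on the two cores compared, but each step lies within the scatter, so the series does not show that either change truly moves the number, and two cores give only one comparison per change.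

The compounds shown carry only bromo, fluoro and trifluoromethyl at these two places, so the effect of an amine, a carboxylic acid or a longer chain there remains open. Going by these compounds, whether these steps would hold on a further core also remains open.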